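Pyridin-2-yl in place of 2-methoxyphenyl on the sulfonyl sulfur

The source may hold more compounds than are shown below. What is called first, only, known or untested is meant among the compounds shown, and "the series" means these compounds.

Three compounds share one core and differ only in the group on the sulfonyl sulfur. Compound 1 `COc1cc(C(=O)NS(=O)(=O)c2cccs2)ccc1Cn1ccc2ccc(NC(=O)CC3CCCC3)cc21` gives 9.6 in a functional assay (trachea) for antagonist activity, with Cavia porcellus as the target; a lower number here means a less potent compound, a higher number a more potent compound, by a factor of ten per unit of this negative logarithm. Compound 2 `COc1cc(C(=O)NS(=O)(=O)c2ccccc2Cl)ccc1Cn1ccc2ccc(NC(=O)CC3CCCC3)cc21` gives 9.8 in this assay, and compound 3 `COc1cc(C(=O)NS(=O)(=O)c2ccccc2OC)ccc1Cn1ccc2ccc(NC(=O)CC3CCCC3)cc21` gives 9.7 in this assay. Compound 3 stands second highest of the three numbers, and all three steps between them, a number 0.20 log units higher from compound 1 to compound 2 (within the scatter), a number 0.10 log units higher from compound 1 to compound 3 (within the scatter) and a number 0.10 log units lower from compound 2 to compound 3 (within the scatter), lie within the scatter.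

Compound 4 `COc1cc(C(=O)NS(=O)(=O)c2ccccn2)ccc1Cn1ccc2ccc(NC(=O)CC3CCCC3)cc21` has not yet been measured. It differs from compound 3 by pyridin-2-yl in place of 2-methoxyphenyl on a sulfonyl sulfur. Going by the values given here, the steps that bear on this are the earlier exchanges of the group on the sulfonyl sulfur, a number 0.20 log units higher from compound 1 to compound 2 (within the scatter) and a number 0.10 log units higher from compound 1 to compound 3 (within the scatter), neither of which moved the number beyond the scatter. A further exchange at the same place is therefore expected to give a step of a number 0.10 log units lower from compound 3 to compound 4 (within the scatter) that stays within the scatter, in no clear direction. Compound 4 is thus estimated at 9.6, with an expected range from 9.1 to 10.1.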

Compound 4, negative logarithm of the antagonist equilibrium constant: 8.9
Compound 4: the middle estimate sits 0.70 log units above what was measured; the whole stated range lies above it.
By their numbers in this assay, from the lowest: compound 4; then compounds 1, 3 and 2 (each within the scatter of the next).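

In this assay the group on the sulfonyl sulfur proves not to be freely exchangeable: thiophen-2-yl, 2-chlorophenyl and 2-methoxyphenyl all lay within the scatter of one another, whereas pyridin-2-yl gives a number 0.80 log units lower from compound 3 to compound 4 (beyond the scatter) and a number 0.90 log units lower from compound 2 to compound 4 (beyond the scatter) and a number 0.70 log units lower from compound 1 to compound 4 (beyond the scatter) with each step beyond the scatter. Pyridin-2-yl, the only six-membered aromatic ring here with a hetero atom, is thus the first group at this place to move the number, and it lowers it against all three earlier groups. No measurement at hand speaks to the cause of this drop.

From the compounds shown here alone, what pyridin-3-yl, pyridin-4-yl or an unsubstituted phenyl would give on the sulfonyl sulfur stays open. The compounds shown therefore cannot tell whether the drop belongs to pyridin-2-yl alone or to pyridine rings at this place in general.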